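This account rests on a few compounds, and the source may have more. Where it says the series, first, only, none or still open, it means among the compounds named here.

Measured so far:

Compound 1, `CCOC(=O)CCCCCOc1cccc(CN(C(=O)c2ccc(-c3cccc(N(C)C)c3)cc2)C(C)C)c1`. In an ADME assay on Raji cells (Homo sapiens) for cytotoxicity, read by CellTiter-Glo and resazurin assay, with a stated time of 72 h (a higher number here means that more compound is needed for the effect, a lower number that less compound is needed), compound 1 gives > 26000 nM, which is a limit of the assay rather than a number.
Compound 2, `CCOC(=O)CCCCCOc1cccc(CN(C(=O)c2ccc(-c3cccc(-c4ccccc4)c3)cc2)C(C)C)c1`. In this assay compound 2 gives > 26000 nM, again a limit.

Both measured values sit at the same point, as the limit of > 26000 nM in this assay, at which 2 of the 2 values shown sit, shows, so the step that the two limits leave unreadable from compound 1 to compound 2 cannot be read: it may be large or nothing at all. Among the compounds with values here, compound 2 therefore stands only at a limit in this assay, and the one further value shown is a limit as well, so nothing here separates the two compounds.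

Compound 3, `CCOC(=O)CCCCCOc1cccc(CN(C(=O)c2ccc(-c3cnc(OC)nc3OC)cc2)C(C)C)c1`, has not yet been measured. It differs from compound 2 in one place: 2,4-dimethoxypyrimidin-5-yl in place of 3-phenylphenyl on an aromatic carbon. Within the data shown here, the single measured step, a step that the two limits leave unreadable from compound 1 to compound 2, bears on this change only in a weak way, since it too alters the group at this place and left the reading at the limit. On that basis no movement beyond the scatter is expected, and the most likely outcome for compound 3 is once more a limit. The expected step is a step that the limit leaves unreadable from compound 2 to compound 3. Compound 3 is estimated at 30000 nM, with a range from 8000 nM to 120000 nM.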

Compound 3, half-maximal effective concentration: > 26000 nM
Compound 3: only a limit was reported; the forecaster's own chance of this, stated with the estimate: 80%; the middle value does not contradict the limit.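

In this assay compound 3 gives > 26000 nM, which is a limit of the assay and not a number. No step among compound 1, compound 2 and compound 3 can be read, because all three rest at the same point: the limit of > 26000 nM in this assay, at which 3 of the 3 values shown sit.

The compounds shown leave open how much of each is actually needed for the effect, and whether changing this group alters that amount at all.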